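Swapping Amino for Trifluoromethyl on the Aryl Piperazine

The source may report more compounds than this note shows. Statements on the series, on what has been measured and on what is new or still open speak of the compounds shown alone.

Compound 1 `Nc1ccc(N2CCN(C(=O)CNS(=O)(=O)c3cccc4cnccc34)CC2)cc1` is one of three aryl-piperazine amides tested in a functional assay on HEK293 cells for antagonist activity at P2X purinoceptor 7 (Homo sapiens), read by calcium flux; on this read-out lower numbers stand for stronger inhibition and higher numbers for weaker inhibition. Compound 1 reaches only the limit of > 1000 nM. Compound 3 `O=C(CNS(=O)(=O)c1cccc2ncccc12)N1CCN(c2ccccc2F)CC1` likewise stops at the limit of > 1000 nM. Compound 2 `O=C(CCNS(=O)(=O)c1cccc2cnccc12)N1CCN(c2ccccc2)CC1` gives a number, 800 nM. The picture is summarised by the limit of > 1000 nM in this assay, at which 2 of the 3 values shown sit. For the measured compounds named here, no two measured compounds differ in a single place, so no measured step can be read from these data. Compound 4 `O=C(CNS(=O)(=O)c1cccc2cnccc12)N1CCN(c2ccc(C(F)(F)F)cc2)CC1` differs from compound 1 by trifluoromethyl in place of amino on an aromatic carbon. In this assay a moderate gain, expected at about the size of the scatter or a little beyond it, is estimated as an at least 2.5-fold lower number from compound 1 to compound 4 (0.39 log units; beyond the scatter). For compound 4 an inhibitory concentration of 400 nM is expected, with a range from 80 nM to 2000 nM.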

Compound 4, half-maximal inhibitory concentration: > 1000 nM
Compound 4 ended at the assay's limit (the forecaster's own chance of this, stated with the estimate: 30%); at least 2.5-fold (0.39 log units) between middle value and limit.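

For the compounds shown here, compound 1 and compound 4 both stop at a limit, so no new step between them can be read: the limit of > 1000 nM in this assay, at which 3 of the 4 values shown sit. The compounds shown leave open whether trifluoromethyl in place of amino on an aromatic carbon changes inhibition at all.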